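This account rests on a few compounds, and the source may have more. Where it says the series, first, only, none or still open, it means among the compounds named here.

compound 1 `O=C(NCc1ccc(S(=O)(=O)c2cccc(C(F)(F)F)c2)cc1)N1Cc2ccncc2C1`: 2.7 nM
compound 2 `CN1CCC(S(=O)(=O)c2ccc(CNC(=O)N3Cc4ccncc4C3)cc2)CC1`: 99 nM

In a functional assay on A2780 cells (Homo sapiens) for cytotoxicity, read by sulforhodamine B assay, with a stated time of 72 h (a lower number here means a stronger inhibitor, a higher number a weaker inhibitor), compound 2 at 99 nM holds the higher of the two numbers. Compound 3 `O=C(NCc1ccc(S(=O)(=O)N2CCC[C@@H](O)C2)cc1)N1Cc2ccncc2C1` differs from it by one change (3-hydroxypiperidin-1-yl in place of 1-methylpiperidin-4-yl on a sulfonyl sulfur), 3-hydroxypiperidin-1-yl in place of 1-methylpiperidin-4-yl on a sulfonyl sulfur. Going by the values given here, one measured step bears on this, at the same kind of sulfur, and it is large (a 37-fold higher number from compound 1 to compound 2 (1.56 log units; beyond the scatter)), so this assay clearly responds to the group there. The expected step (a 5.5-fold lower number from compound 2 to compound 3 (0.74 log units; beyond the scatter)) runs towards a lower number and stays smaller than that measured one. For compound 3 the estimate is 18 nM (expected range 4 nM to 80 nM).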

Compound 3, half-maximal inhibitory concentration: 70 nM
Compound 3: the middle estimate sits 3.9-fold (0.59 log units) below what was measured; measured number inside the range.
By their numbers in this assay, from the lowest: compound 1; then compounds 3 and 2 (each within the scatter of the next).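

In this assay the change from 1-methylpiperidin-4-yl to 3-hydroxypiperidin-1-yl on the sulfonyl sulfur gives a 1.4-fold lower number from compound 2 to compound 3 (0.15 log units; within the scatter) and so does not separate these two six-membered non-aromatic rings. The 3-(trifluoromethyl)phenyl of compound 1 stays apart from the second such ring as well, with a 26-fold higher number from compound 1 to compound 3 (1.41 log units; beyond the scatter) as the step at this position. Nothing available explains either step.

Open, from the compounds shown here alone, is whether a plain phenyl or a pyridine on the sulfonyl sulfur comes close to compound 1. Also open, going by these compounds, is what an unsubstituted piperidin-1-yl or the opposite hydroxyl stereocentre would give.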